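The source may hold more compounds than are shown below. What is called first, only, known or untested is meant among the compounds shown, and "the series" means these compounds.

Compound 1 `CCOc1ccccc1-n1nncc1CN1C(=O)C2(C(C#N)=C(N)Oc3c2c2nc4ccccc4nc2c2ccccc32)c2ccccc21` was tested in a functional assay on A549 cells (Homo sapiens) for antiproliferative activity, read by MTT assay, with a stated time of 48 h (a higher number here means a weaker inhibitor, a lower number a stronger inhibitor), and in that assay compound 1 gives only the limit > 50000 nM. Compound 2 `Cc1cc(C)cc(-n2nncc2CN2C(=O)C3(C(C#N)=C(N)Oc4c3c3nc5ccccc5nc3c3ccccc43)c3ccccc32)c1` gives only the limit > 50000 nM. The step that the two limits leave unreadable from compound 1 to compound 2 stays unreadable because the limit of > 50000 nM in this assay, at which 3 of the 3 values shown sit, covers both ends of it. Compound 3 `N#CC1=C(N)Oc2c(N)cc3nc4ccccc4nc3c2C12C(=O)N(Cc1cnnn1-c1ccc(F)cc1)c1ccccc12` stands at the same place: in this assay compound 3 gives only the limit > 50000 nM. Compound 4 `COc1ccc(-n2nncc2CN2C(=O)C3(C(C#N)=C(N)Oc4c(N)cc5nc6ccccc6nc5c43)c3ccccc32)cc1` is not yet measured; it differs from compound 3 by methoxy in place of fluoro on an aromatic carbon. No measured step bears on this change, and the single step shown is itself unreadable. Compound 4 is therefore expected to remain at the limit, with an estimated step that the limit leaves unreadable from compound 3 to compound 4 of no readable size. Compound 4 is estimated at 60000 nM, with a range from 20000 nM to 200000 nM.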

Compound 4, half-maximal inhibitory concentration: > 50000 nM
Compound 4 was reported as a limit; the forecaster's own chance of this, stated with the estimate: 85%; the middle value is on the limit's open side.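

No new step can be read: the change from compound 3 to compound 4 stays unreadable because both compounds give only a limit: the limit of > 50000 nM in this assay, at which 4 of the 4 values shown sit. The compounds shown leave open which change on the shared core, if any, would give a measurable value in this assay.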